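Swapping a Methoxynaphthyl Group for a Styryl Chain

The compounds below may be only part of what the source reports. "The series", "measured", "known", "first", "only" and "open" are said of these compounds alone.

Compound 1 `COc1cc(N2C(N)=C(C#N)C(c3ccc(OC)c4ccccc34)C3=C2CC(C)(C)CC3=O)cc(OC)c1OC` — in a functional assay on Ehrlich cells (Mus musculus) for cytotoxicity (on this read-out lower numbers stand for stronger inhibition and higher numbers for weaker inhibition), compound 1 gives "not active" (no number reported)
Compound 2 `COc1ccccc1C1C(C#N)=C(N)N(c2cc(OC)c(OC)c(OC)c2)C2=C1C(=O)CC(C)(C)C2` — in this assay compound 2 gives 26600 nM
Compound 3 `COc1cc(N2C(N)=C(C#N)C(c3ccc([N+](=O)[O-])cc3)C3=C2CC(C)(C)CC3=O)cc(OC)c1OC` — in this assay compound 3 gives 25000 nM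

Compound 1 has no single number in this assay; it is reported only as inactive and so cannot be placed on the scale beside the others. Compound 4 `COc1cc(N2C(N)=C(C#N)C(/C=C/c3ccccc3)C3=C2CC(C)(C)CC3=O)cc(OC)c1OC` arises from compound 1 by 2-phenylethenyl in place of 4-methoxynaphthalen-1-yl on a saturated ring carbon. Going by the values given here, the only measured step, a 1.1-fold lower number from compound 2 to compound 3 (0.03 log units; within the scatter), exchanges a different aromatic group on the same carbon and lies within the scatter; it does not involve the group that enters here, so no measured step bears directly on this change. Compound 2 and compound 3 sit near each other, and compound 1 lacks a number. Compound 4 is therefore expected to inhibit only weakly, estimated at 30000 nM (range 10000 nM to 100000 nM).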

Compound 4, half-maximal inhibitory concentration: "not active" (no number reported)
Compound 4 has no reported number here; the estimate stays without a comparison.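

In this assay compound 1 and compound 4 are both reported only as inactive, without a number, so no step can be read between them, and nothing measured here offers an explanation. As far as these compounds go, whether 2-phenylethenyl and 4-methoxynaphthalen-1-yl differ at all in strength stays open.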